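This account rests on a few compounds, and the source may have more. Where it says the series, first, only, none or still open, it means among the compounds named here.

Three compounds sharing one core have numbers in a functional assay (Homo sapiens) for inhibition; on this read-out higher numbers stand for weaker inhibition and lower numbers for stronger inhibition: compound 1 `CS(=O)(=O)c1ccc(CSc2nc(-c3ccc(F)cc3)c(-c3ccncc3)[nH]2)cc1` gives 330 nM, compound 2 `CSc1cccc(CSc2nc(-c3ccc(F)cc3)c(-c3ccncc3)[nH]2)c1` gives 550 nM and compound 3 `C[S+]([O-])c1ccc(CCSc2nc(-c3ccc(F)cc3)c(-c3ccncc3)[nH]2)cc1` gives 500 nM. Compound 3 stands within the scatter of both others, with a 1.1-fold lower number from compound 2 to compound 3 (0.04 log units; within the scatter) as its closest comparison. Compound 4 `C[S+]([O-])c1ccc(CCCSc2nc(-c3ccc(F)cc3)c(-c3ccncc3)[nH]2)cc1` is not yet measured and carries a group of 10 heavy atoms (8 carbon, 1 oxygen, 1 sulfur; one six-membered aromatic ring of carbon only) in place of a group of 9 heavy atoms (7 carbon, 1 oxygen, 1 sulfur; one six-membered aromatic ring of carbon only), on a saturated chain carbon, two bonds along the chain from a sulfur.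

Among the measured compounds shown here, no measured step isolates this exact change. For the measured compounds named here, the steps that bear on it are indirect: a 1.5-fold higher number from compound 1 to compound 3 (0.18 log units; within the scatter), and a 1.7-fold higher number from compound 1 to compound 2 (0.22 log units; within the scatter). Each replaces the group on the saturated chain carbon bound to a sulfur, and neither goes beyond the scatter. On that limited evidence, no step beyond the scatter is expected in this assay, and no direction is favoured. The expected step is no change at the digits printed from compound 3 to compound 4 (within the scatter). For compound 4 the estimated value is 500 nM, with an expected range of 200 nM to 1250 nM.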

Compound 4, half-maximal inhibitory concentration: 180 nM
For compound 4 the middle estimate is 2.8-fold (0.44 log units) above the measured one, outside the stated range (below it).
By their numbers in this assay, from the lowest: compounds 4, 1, 3 and 2 (each within the scatter of the next, the first and the last beyond it).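

In this assay the series shows a 2.8-fold lower number from compound 3 to compound 4 (0.44 log units; beyond the scatter) while the steps among compound 1, compound 2 and compound 3 all stay within the scatter. This place, on a saturated chain carbon, two bonds along the chain from a sulfur, is therefore not indifferent to the change. The group of 10 heavy atoms (8 carbon) in place of the group of 9 heavy atoms (7 carbon) moves the number, with oxygen, sulfur, the aromatic ring and the hydrogen-bond donor and acceptor counts the same in both groups, and no measurement shown here accounts for the step.

On these data alone, whether a longer chain at this place lowers the number further or reverses the step stays open. Also open, as far as these compounds go, is whether an amine or a carboxylic acid on the aromatic ring keeps the lower number.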